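The source may report more compounds than this note shows. Statements on the series, on what has been measured and on what is new or still open speak of the compounds shown alone.

Measured so far in a functional assay on HepG2 cells (Homo sapiens) for antiproliferative activity, read by sulforhodamine B assay, with a stated time of 72 h; on this read-out higher numbers stand for weaker inhibition and lower numbers for stronger inhibition:
compound 1, `CC(C)[C@@H](NC(=O)OC(C)(C)C)C(=O)Nc1ccc2ncnc(Nc3ccc(F)c(Cl)c3)c2c1`: > 50000 nM
compound 2, `CC(C)C[C@@H](NC(=O)OC(C)(C)C)C(=O)Nc1ccc2ncnc(Nc3ccc(F)c(Cl)c3)c2c1`: 13800 nM
compound 3, `CC(C)[C@@H](NC(=O)OC(C)(C)C)C(=O)Nc1ccc2ncnc(Nc3cccc(C(F)(F)F)c3)c2c1`: 4300 nM

The value of compound 1 is a limit of this assay, not a number (the limit of > 50000 nM in this assay, at which 1 of the 3 values shown sits). From compound 1 to compound 2 the change is isobutyl in place of isopropyl on a saturated chain carbon bound to an amide-type nitrogen and a carbonyl carbon, and the step is an at least 3.6-fold lower number from compound 1 to compound 2 (0.55 log units; beyond the scatter). From compound 1 to compound 3 the change is 3-(trifluoromethyl)phenyl in place of 3-chloro-4-fluorophenyl on a nitrogen on an aromatic ring, and the step is an at least 11-fold lower number from compound 1 to compound 3 (1.06 log units; beyond the scatter). Compound 3 shows the lowest number among those counted.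

Compound 4, `CC(C)C[C@@H](NC(=O)OC(C)(C)C)C(=O)Nc1ccc2ncnc(Nc3cccc(C(F)(F)F)c3)c2c1`, is not yet measured. It differs from compound 3 by isobutyl in place of isopropyl on a saturated chain carbon bound to an amide-type nitrogen and a carbonyl carbon, the same change as from compound 1 to compound 2, on the same place. Going by that earlier step, compound 4 is expected to show a 2.9-fold lower number from compound 3 to compound 4 (0.46 log units; beyond the scatter) in this assay, though the earlier step started from a limit and its true size is not known. The estimate for compound 4 is 1500 nM, between 500 nM and 5000 nM.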

Compound 4, half-maximal inhibitory concentration: > 50000 nM
Compound 4 gave a limit, no number (the forecaster's own chance of this, stated with the estimate: 2%); middle value at least 33-fold (1.52 log units) away from the limit.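

Compound 4 gives > 50000 nM in this assay, a limit of the assay and not a number. Isobutyl in place of isopropyl gives an at least 11-fold higher number from compound 3 to compound 4 (1.06 log units; beyond the scatter), so in these compounds the step does not carry its direction from one core to the other: the same change on two cores in this assay, an at least 3.6-fold lower number (0.55 log units; beyond the scatter) from compound 1 to compound 2 and an at least 11-fold higher number (1.06 log units; beyond the scatter) from compound 3 to compound 4, at least 42-fold (1.62 log units) apart, beyond the scatter of two such steps. 3-(Trifluoromethyl)phenyl in place of 3-chloro-4-fluorophenyl gives an at least 3.6-fold higher number from compound 2 to compound 4 (0.55 log units; beyond the scatter), which likewise reverses direction, though limits leave the true sizes of these steps unknown and four compounds show no general rule: the same change on two cores in this assay, an at least 11-fold lower number (1.06 log units; beyond the scatter) from compound 1 to compound 3 and an at least 3.6-fold higher number (0.55 log units; beyond the scatter) from compound 2 to compound 4, at least 42-fold (1.62 log units) apart, beyond the scatter of two such steps.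

On these data alone, it stays open whether a longer chain than isobutyl on the same saturated chain carbon would follow either core. The same question stands for a free amine in place of the tert-butyl carbamate.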